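Halogen exchange on the benzyl ring: iodo to fluoro

A few compounds are considered here, and "the series" means these few. Any claim that something is new, unique, unknown or untested is made for them only; others in the source may bear on it.

Compound 2 `O[C@@H]1[C@H](O)CS[C@H]1Cn1cnc2c(NCc3cccc(I)c3)ncnc21` stands highest of the two numbers in an assay on CHO cells for displacement of a labelled ligand from adenosine receptor A1 (Homo sapiens), with a stated time of 60 min, tested at 10 uM (on this read-out lower numbers stand for less inhibition and higher numbers for more inhibition at the one concentration tested (going by the name of the read-out)), giving 9.6%; compound 1 `O[C@@H]1[C@H](O)CS[C@H]1Cn1cnc2c(NCc3cccc(Cl)c3)ncnc21` is nearest, with 3.3%, and the two lie within the scatter. Compound 3 `O[C@@H]1[C@H](O)CS[C@H]1Cn1cnc2c(NCc3cccc(F)c3)ncnc21` differs from compound 2 by fluoro in place of iodo on an aromatic carbon. For the measured compounds named here, the only measured step bearing on this is the halogen exchange on the same carbon, and because a number 6.3 percentage points higher from compound 1 to compound 2 (within the scatter) stayed within the scatter, no step beyond the scatter is expected here either, a number 5.6 percentage points lower from compound 2 to compound 3 (within the scatter). Compound 3 is therefore estimated at 4%, within -6% to 15%.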

Compound 3, a percentage reported as inhibition, at one concentration (the size of the read-out at that concentration, not a potency): 0.3%
Compound 3: middle estimate off by 3.7 percentage points, on the high side, and the stated range covers the measured number.
By their numbers in this assay, from the lowest: compounds 3, 1 and 2 (each within the scatter of the next).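

In this assay, fluoro on an aromatic carbon of the benzyl ring gives a number 9.3 percentage points lower from compound 2 to compound 3 (within the scatter), and, set against chloro, a number 3 percentage points lower from compound 1 to compound 3 (within the scatter). Iodo, chloro and fluoro at this place therefore read alike, so the halogen exchange has shown no step beyond the scatter at the one concentration tested. Nothing measured here offers an explanation for this. Still open, going by these compounds, is whether a non-halogen group on this carbon, such as an amine, a carboxylic acid or a methoxy group, would give a step beyond the scatter.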